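A few compounds are considered here, and "the series" means these few. Any claim that something is new, unique, unknown or untested is made for them only; others in the source may bear on it.

The measured compounds:

Compound 1, `CCOC(=O)c1cnn(-c2nc(-c3ccccc3O)c(C#N)c(=O)n2C)c1N`, gives 57 ug/mL in a functional assay on microsomes for inhibition, with a stated time of 1 h; on this read-out higher numbers stand for weaker inhibition and lower numbers for stronger inhibition.
Compound 2, `Cn1c(NN)nc(-c2ccccc2O)c(C#N)c1=O`, gives 34 ug/mL in this assay.
Compound 3, `CCOC(=O)c1cnn(-c2nc(-c3ccccc3Cl)c(C#N)c(=O)n2C)c1N`, gives 102 ug/mL in this assay.

Compound 2 shows the lowest of the three numbers. Its nearest neighbour is compound 1, and the gap between them lies within the usual scatter of repeated measurements, so no order between the two can be claimed. Compound 3 stands furthest from compound 2, and that gap lies beyond the scatter. The difference between the core of compound 1 and the core of compound 2 is not broken down here. Compound 1 and compound 3 differ in one place only, (chloro in place of hydroxy on an aromatic carbon), and this change gave a 1.8-fold higher number from compound 1 to compound 3 (0.25 log units; within the scatter).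

Compound 4, `Cn1c(NN)nc(-c2ccccc2Cl)c(C#N)c1=O`, has not yet been measured in this assay. It differs from compound 2 by chloro in place of hydroxy on an aromatic carbon, the same change as that between compound 1 and compound 3, at a place described in the same words. Among the compounds with values here, only one measured instance of this change exists, so the expectation for compound 4 rests on compound 1 and compound 3, because a 1.8-fold higher number from compound 1 to compound 3 (0.25 log units; within the scatter) is the only guide available. Compound 4 is therefore expected to give about 60 ug/mL in this assay, most likely between 30 ug/mL and 120 ug/mL. This amounts to an expected 1.8-fold higher number from compound 2 to compound 4 (0.25 log units; within the scatter), a step of about the same size as the earlier one.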

Compound 4, half-maximal inhibitory concentration: 57 ug/mL
Compound 4: the middle estimate sits 1.1-fold (0.02 log units) above what was measured; low and high end bracket the measured number.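

In this assay, chloro in place of hydroxy on an aromatic carbon gave a 1.7-fold higher number from compound 2 to compound 4 (0.22 log units; within the scatter), and this step on the core of compound 2 matches the step seen earlier on the core of compound 1: the same change on two cores in this assay, a 1.8-fold higher number (0.25 log units; within the scatter) from compound 1 to compound 3 and a 1.7-fold higher number (0.22 log units; within the scatter) from compound 2 to compound 4, 1.1-fold (0.03 log units) apart, within the scatter of two such steps. Across these two cores, then, the change carried over with no detectable difference in the size of its step, so the single earlier step proved a fair guide on the second core. This does not show that chloro and hydroxy truly differ on this read-out, as each step on its own lies within the scatter, and two cores give no general rule for carrying the change to other cores in the series.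

The compounds shown have only hydroxy or chloro on this aromatic carbon, so it remains open how a methoxy group, an amine or a fluoro group there would read in this assay. From the compounds shown here alone, it also remains open whether the same agreement between cores would hold on a core bearing a carboxylic acid in place of the ethyl ester of compound 1 and compound 3.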